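A few compounds are considered here, and "the series" means these few. Any claim that something is new, unique, unknown or untested is made for them only; others in the source may bear on it.

Compound 1 `Cc1ccc(Cn2c(N3CCNCC3)cc(=O)n3nccc23)cc1` is known in an ADME assay on isolated protein for inhibition of Dipeptidyl peptidase 9 (Homo sapiens), read by fluorescence, with a stated time of 10 min (on this read-out higher numbers stand for weaker inhibition and lower numbers for stronger inhibition), only by a limit: compound 1 gives > 100000 nM, which is a limit of the assay and not a number. Compound 2 `O=c1cc(N2CCNCC2)n(Cc2ccccc2)c2ccnn12` likewise reaches only a limit, and in this assay compound 2 gives > 100000 nM. Going by the values given here, the one measured step, a step that the two limits leave unreadable from compound 1 to compound 2, is therefore unreadable, and the evidence amounts to the limit of > 100000 nM in this assay, at which 2 of the 2 values shown sit. The change to compound 3 `Cc1ccc(Cn2c(N3CCC[C@@H](N)C3)cc(=O)n3nccc23)cc1` is 3-aminopiperidin-1-yl in place of piperazin-1-yl on an aromatic carbon. Among the compounds with values here, no measured step bears on this change, since the pair of limits shows neither its size nor its direction, and the change itself is of a different kind from the one that was measured. Compound 1 being held at a limit, the expected step of an at least 3.3-fold lower number from compound 1 to compound 3 (0.52 log units; beyond the scatter) is a guess from the starting point alone, and compound 3 is estimated at 30000 nM in this assay, with a range from 5000 nM to 150000 nM.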

Compound 3, half-maximal inhibitory concentration: > 100000 nM
Compound 3: only a limit was reported; the forecaster's own chance of this, stated with the estimate: 55%; middle value at least 3.3-fold (0.52 log units) from the limit.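

In this assay compound 3 reaches only a limit, as compound 1 does, so the step from compound 1 to compound 3 cannot be read. The compounds shown leave open how strongly any of them inhibits this enzyme, and whether either change shifts that inhibition: the limit of > 100000 nM in this assay, at which 3 of the 3 values shown sit.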